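Ring-amine substituent on the dichlorobenzyl ether series

The source may hold more compounds than are shown below. What is called first, only, known or untested is meant among the compounds shown, and "the series" means these compounds.

Compound 2 `CN1CCC[C@H](OCc2cc(Cl)cc(Cl)c2)[C@@H]1c1ccccc1` reaches only a limit in an assay on isolated protein for activation of cGMP-dependent protein kinase 1 (Homo sapiens), read by ADP-Glo, with stated times of 120 min and 40 min (a higher number here means that more compound is needed for the effect, a lower number that less compound is needed), giving > 200000 nM. Its limit is the one where (the limit of > 200000 nM in this assay, at which 1 of the 3 values shown sits). Going by the values given here, compound 1 `OC[C@@H](O[C@H]1CCCN(Cc2ncc[nH]2)[C@H]1c1ccccc1)c1cc(Cl)cc(Cl)c1` gives 7000 nM and compound 3 `OC[C@@H](O[C@H]1CCCN(Cc2ccc(-c3nn[nH]n3)cc2)[C@H]1c1ccccc1)c1cc(Cl)cc(Cl)c1` gives 131000 nM; the step of a 19-fold higher number from compound 1 to compound 3 (1.27 log units; beyond the scatter) is the only measured change at the same place. That step swaps one ring for another, whereas compound 4 `COc1cc(C(=O)O)ccc1CN1CCC[C@H](OCc2cc(Cl)cc(Cl)c2)[C@@H]1c1ccccc1` differs from compound 2 by 4-carboxy-2-methoxyphenyl in place of hydrogen on a saturated chain carbon bound to an amine nitrogen in a ring. Compound 2 cannot be read as a number, so the expected step is uncertain in size; the measured step gives no sign that a large aryl carrying an acid group helps. Compound 4 is therefore expected near the limit, estimated at 120000 nM (range 30000 nM to 400000 nM), meaning an expected step of an at least 1.6-fold lower number from compound 2 to compound 4 (0.22 log units; that floor lies within the scatter).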

Compound 4, half-maximal effective concentration: 62000 nM
For compound 4 the middle estimate is 1.9-fold (0.29 log units) above the measured one, within the range that was stated.
By their numbers in this assay, from the lowest: compound 1; then compound 4; then compound 3. At a limit, above all of these: compound 2.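

In this assay, 4-carboxy-2-methoxyphenyl in place of hydrogen on a saturated chain carbon bound to an amine nitrogen in a ring gives an at least 3.2-fold lower number from compound 2 to compound 4 (0.50 log units; beyond the scatter). Going by these compounds alone, this is the first read-out of a substituent against hydrogen at this place, and it points to a lower number, whereas the earlier step only exchanged one ring-bearing group for another. Compound 2 stands at a limit, so the step gives only a floor: the limit of > 200000 nM in this assay, at which 1 of the 4 values shown sits.

On these data alone, it remains open which part of 4-carboxy-2-methoxyphenyl goes with the step. A plain benzyl group, or a primary amide or an amine in place of the carboxylic acid, would separate the ring from the acid.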